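The source may report more compounds than this note shows. Statements on the series, on what has been measured and on what is new or still open speak of the compounds shown alone.

In a functional assay on MCF7 cells (Homo sapiens) for inhibition, read by sulforhodamine B assay, with a stated time of 48 h (a higher number here means a weaker inhibitor of growth, a lower number a stronger inhibitor of growth), three compounds sharing one core have been measured. Compound 1 `CC1(/C=C/c2ccccc2)C=CC(=O)O1` gives 95300 nM, compound 3 `COc1cc(/C=C/C2(C)C=CC(=O)O2)cc(OC)c1OC` gives 56600 nM, and compound 2 `CC1(/C=C/c2ccccc2C(F)(F)F)C=CC(=O)O1` gives 13500 nM, the lowest of the three numbers. Compound 4 `CC1(/C=C/c2ccccc2O)C=CC(=O)O1` departs from compound 2 with hydroxy in place of trifluoromethyl on an aromatic carbon. Among the measured compounds shown here, only one measured step bears on this change: a 7.1-fold lower number from compound 1 to compound 2 (0.85 log units; beyond the scatter), a modest step that came with trifluoromethyl in place of hydrogen on an aromatic carbon. For the measured compounds named here, no hydroxy compound has been measured, so nothing shows whether hydroxy would keep that gain. Compound 4 is expected to give back part of the step, landing at a higher number than compound 2 at 13500 nM but a lower one than compound 1 at 95300 nM. The expected size of the change is a 3.0-fold higher number from compound 2 to compound 4 (0.47 log units; beyond the scatter). In this assay, compound 4 is estimated at 40000 nM, with an expected range from 13000 nM to 110000 nM.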

Compound 4, concentration for total growth inhibition: 46200 nM
Compound 4: the middle estimate sits 1.2-fold (0.06 log units) below what was measured, within the range that was stated.
By their numbers in this assay, from the lowest: compound 2; then compounds 4, 3 and 1 (each within the scatter of the next, the first and the last beyond it).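

In this assay, the aromatic carbon that had shown a gain only with trifluoromethyl now shows one with a second group, as hydroxy in place of hydrogen brings a 2.1-fold lower number from compound 1 to compound 4 (0.31 log units; beyond the scatter) and the lower number is thus not confined to trifluoromethyl. The two groups are not equivalent at this carbon, since exchanging trifluoromethyl for hydroxy brings a 3.4-fold higher number from compound 2 to compound 4 (0.53 log units; beyond the scatter) and leaves compound 4 with only part of the gain seen for compound 2. Nothing available here explains why the two groups differ.

From the compounds shown here alone, whether an amine or a nitrile on the same carbon would land nearer compound 2 or compound 1 remains open. Also open, going by these compounds, is whether hydroxy and trifluoromethyl would keep this order on another carbon of the same ring.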